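The source may report more compounds than this note shows. Statements on the series, on what has been measured and on what is new or still open speak of the compounds shown alone.

Compound 1, `O=c1[nH]cnc2c1c(-c1ccco1)cn2[C@@H]1O[C@H](CO)[C@@H](O)[C@H]1O`, gives 15500 nM in a functional assay on K562 cells (Homo sapiens), read by MTT assay, with a stated time of 72 h; on this read-out lower numbers stand for stronger inhibition and higher numbers for weaker inhibition.
Compound 2, `O=c1[nH]cnc2c1c(-c1cc3ccccc3o1)cn2[C@@H]1O[C@H](CO)[C@@H](O)[C@H]1O`, reaches only the limit of > 20000 nM in this assay, a value that is a limit and not a number.
Compound 3, `Nc1nc(N)c2c(-c3cc4ccccc4o3)cn([C@@H]3O[C@H](CO)[C@@H](O)[C@H]3O)c2n1`, gives 18600 nM in this assay.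

Compound 1 and compound 2 share a core and differ only by furan-2-yl in place of 1-benzofuran-2-yl on an aromatic carbon, a change that brought an at least 1.2-fold lower number from compound 2 to compound 1 (0.11 log units; that floor lies within the scatter). Compound 3 carries a different core, and the difference between the two cores is not broken down here; its value and that of compound 1 lie within the usual scatter of each other. Compound 4, `Nc1nc(N)c2c(-c3ccco3)cn([C@@H]3O[C@H](CO)[C@@H](O)[C@H]3O)c2n1`, is not yet measured and differs from compound 3 by furan-2-yl in place of 1-benzofuran-2-yl on an aromatic carbon, the same change at the same place. Compound 4 is expected to show a 1.3-fold lower number from compound 3 to compound 4 (0.12 log units; within the scatter) in this assay, resting on the step seen from compound 2 to compound 1, which was bounded by the limit of > 20000 nM in this assay, at which 1 of the 3 values shown sits. Compound 4 is therefore estimated at 14000 nM, between 6000 nM and 30000 nM.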

Compound 4, half-maximal inhibitory concentration: > 20000 nM
Compound 4: a limit, no number; the forecaster's own chance of this, stated with the estimate: 25%; middle value at least 1.4-fold (0.15 log units) from the limit.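

In this assay, furan-2-yl in place of 1-benzofuran-2-yl on the core of compound 3 gave an at least 1.0-fold higher number from compound 3 to compound 4 (0.03 log units; that floor lies within the scatter). Set beside the earlier step, this does not show whether the change carries over from one core to the other: the same change on two cores in this assay, an at least 1.2-fold lower number (0.11 log units; that floor lies within the scatter) from compound 2 to compound 1 and an at least 1.0-fold higher number (0.03 log units; that floor lies within the scatter) from compound 3 to compound 4; the limit leaves it open whether they differ. Each step rests on a limit and not a number, so neither has a measured size, and the values offer little room for comparison: the limit of > 20000 nM in this assay, at which 2 of the 4 values shown sit.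

The compounds shown leave open how either core responds at this place to an amine, a carboxylic acid or a longer chain. They also leave open how values would change if another group replaced the 3,4-dihydroxy-5-(hydroxymethyl)oxolan-2-yl group.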